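Chain-lengthened hydroxamates on a hydroxamic acid and a lactone core

This account rests on a few compounds, and the source may have more. Where it says the series, first, only, none or still open, it means among the compounds named here.

Measured compounds:
compound 1 `CC(C)CCc1c(OCCCCCCCC(=O)NO)ccc(CCC(=O)NO)c1O` 2670 nM
compound 2 `CC(C)CCc1c(OCCCCC(=O)NO)ccc(CCC(=O)NO)c1O` 10000 nM
compound 3 `CC(C)CCc1c(OCCCCC(=O)NO)ccc2c1OC(=O)CC2` > 30000 nM

In a functional assay on A549 cells (Homo sapiens) for antiproliferative activity, read by sulforhodamine B assay, with a stated time of 48 h (on this read-out lower numbers stand for stronger inhibition of growth and higher numbers for weaker inhibition of growth), compound 2 gives 10000 nM and compound 1 gives 2670 nM. The step between them is a 3.7-fold lower number from compound 2 to compound 1 (0.57 log units; beyond the scatter), and it rests on the change (3-(hydroxycarbamoyl)propyl in place of hydroxycarbamoyl on a saturated chain carbon, four bonds along the chain from an oxygen on an aromatic ring). For compound 3 only a limit of the assay is known, > 30000 nM, as shown by the limit of > 30000 nM in this assay, at which 1 of the 3 values shown sits. How the core of compound 3 differs from the core of compound 2 is not broken down here.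

Compound 4 `CC(C)CCc1c(OCCCCCCCC(=O)NO)ccc2c1OC(=O)CC2` has not yet been measured in this assay. It differs from compound 3 by 3-(hydroxycarbamoyl)propyl in place of hydroxycarbamoyl on a saturated chain carbon, four bonds along the chain from an oxygen on an aromatic ring, the same change that was made from compound 2 to compound 1; among the compounds shown it occurs two times in all. Since compound 3 stands only at a limit, the expected step of an at least 1.5-fold lower number from compound 3 to compound 4 (0.17 log units; that floor lies within the scatter) for compound 4 rests on the step of a 3.7-fold lower number from compound 2 to compound 1 (0.57 log units; beyond the scatter) alone, and its footing is weak. Compound 4 is therefore expected to give about 20000 nM, somewhere between 6000 nM and 60000 nM, with a fair chance that only a limit is reported again.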

Compound 4, concentration for 50% growth inhibition: > 30000 nM
Compound 4: no number, only a limit (the forecaster's own chance of this, stated with the estimate: 40%); at least 1.5-fold (0.17 log units) between middle value and limit.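

In this assay, among the compounds shown here, compound 3 and compound 4 both stand only at a limit of the assay, so no step between them can be read: the limit of > 30000 nM in this assay, at which 2 of the 4 values shown sit.

The compounds shown leave open whether 3-(hydroxycarbamoyl)propyl in place of hydroxycarbamoyl changes growth inhibition at all on the core of compound 3, as it does on the core of compound 2.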